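The source may hold more compounds than are shown below. What is called first, only, known or untested is meant among the compounds shown, and "the series" means these compounds.

Going by the values given here, compound 1 `COc1ccc(SCc2ccc(C(=O)Nc3ccccc3N)cc2)cc1` is the only compound in this set that carries a numeric result: in a functional assay on SMMC-7721 cells (Homo sapiens) for antiproliferative activity, read by CCK-8 assay, with a stated time of 72 h (on this read-out higher numbers stand for weaker inhibition and lower numbers for stronger inhibition), compound 1 gives 2170 nM, so it stands alone and cannot be ranked against a neighbour. Compound 2 `Nc1ccccc1NC(=O)/C=C/c1ccc(CSc2ccc(F)cc2)cc1` was also prepared, but in this assay compound 2 gives "not determined" (no result reported), and nothing can be drawn from it. Compound 3 `Cc1ccc(SCc2ccc(C(=O)Nc3ccccc3N)cc2)cc1` is the next member and has not yet been measured in this assay. Its difference from compound 1 is counted as methyl in place of methoxy on an aromatic carbon. Among the compounds with values here, no step between two measured compounds exists here to show how such a change has behaved. Within the data shown here, with only one reference value, the expected step of a 1.0-fold lower number from compound 1 to compound 3 (0.01 log units; within the scatter) is placed within the usual scatter, with no direction favoured over the other. Compound 3 is therefore estimated at 2100 nM, in a range from 700 nM to 6500 nM.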

Compound 3, half-maximal inhibitory concentration: 3740 nM
The estimate for compound 3 lay 1.8-fold (0.25 log units) below the measured number; low and high end bracket the measured number.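

In this assay the series now has its first readable step, as methyl in place of methoxy on an aromatic carbon, para to a large group, gives a 1.7-fold higher number from compound 1 to compound 3 (0.24 log units; within the scatter) at this position. On this read-out, 4-methoxyphenyl and 4-methylphenyl cannot be told apart, even though the change removes one heavy atom and the one hydrogen-bond acceptor counted in the methoxy group. No available evidence bears on this result.

From the compounds shown here alone, it remains open whether the position would stay as indifferent to a group of another kind, such as an amine, a carboxylic acid or a longer chain, because only methoxy and methyl can be compared here. Going by these compounds, it is also open whether the same exchange would behave alike on another core, and compound 2, which has no number, cannot help to settle that.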